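This account rests on a few compounds, and the source may have more. Where it says the series, first, only, none or still open, it means among the compounds named here.

In an assay on isolated protein for inhibition of Rho-associated protein kinase 2 (Homo sapiens), read by radiometric assay and 33P incorporation, with a stated time of 40 min, in the presence of a further agent that is not named here (on this read-out higher numbers stand for weaker inhibition and lower numbers for stronger inhibition), compound 3 `COc1cccc(Cn2cnc3sc(-c4ccnc(N)c4)cc3c2=O)c1` gives 1 nM, the lowest of the three numbers shown, although compound 1 `COc1cccc(Cn2cnc3sc(-c4ccc5[nH]ncc5c4)cc3c2=O)c1` gives 2 nM and the step of a 2.0-fold lower number from compound 1 to compound 3 (0.30 log units; within the scatter) falls within the scatter, so these two cannot be told apart. Compound 2 `COc1cccc(Cn2cnc3sc(-c4cccnc4)cc3c2=O)c1` gives 3480 nM; the steps of a 1700-fold higher number from compound 1 to compound 2 (3.24 log units; beyond the scatter) and a 3500-fold lower number from compound 2 to compound 3 (3.54 log units; beyond the scatter) are large. Compound 4 `COc1ccc(Cn2cnc3sc(-c4ccnc(N)c4)cc3c2=O)cc1` differs from compound 3 only in 4-methoxyphenyl in place of 3-methoxyphenyl on a saturated chain carbon bound to an aromatic nitrogen. Within the data shown here, none of the measured steps touches this group: all three change the aromatic group on the aromatic carbon while the methoxyphenyl stays the same. Among the measured compounds shown here, no measured step therefore bears on this change, and the expected step of a 2.0-fold higher number from compound 3 to compound 4 (0.30 log units; within the scatter) is set small, within the scatter. Compound 4 is expected to give 2 nM, with a range from 0.5 nM to 10 nM.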

Compound 4, half-maximal inhibitory concentration: 46 nM
For compound 4 the middle estimate is 23-fold (1.36 log units) below the measured one, and the stated range ends below it.
By their numbers in this assay, from the lowest: compounds 3 and 1 (each within the scatter of the next); then compound 4; then compound 2.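

Replacing 3-methoxyphenyl with 4-methoxyphenyl on a saturated chain carbon bound to an aromatic nitrogen gives a 46-fold higher number from compound 3 to compound 4 (1.66 log units; beyond the scatter). Among these compounds, this part of the molecule, unchanged in the earlier steps, therefore also matters for inhibition, and moving the methoxy group alone is enough to change the result, with the same atoms on both sides. No measurement here explains this shift.

On these data alone, it remains open whether a plain phenyl, or a phenyl carrying fluorine or a hydroxyl group instead of methoxy, would fare better or worse. Also open, as far as these compounds go, is whether the same move would matter as much with 1H-indazol-5-yl in place of 2-aminopyridin-4-yl.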